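The source may hold more compounds than are shown below. What is called first, only, known or untested is meant among the compounds shown, and "the series" means these compounds.

Compound 2, `N#CCN(Cc1ccc2ccccc2c1)Cc1ccccc1Br`, gives 0% in an assay on HEK293 cells for binding affinity to Substance-K receptor (Rattus norvegicus), read by FRET, tested at 10 uM (a higher number here means more inhibition at the concentration tested (going by the name of the read-out), a lower number less inhibition), which places it level with compound 1, `N#CCN(Cc1ccc(Br)cc1)Cc1ccc2ccccc2c1`, whose reading in this assay is 0%. Among the measured compounds shown here, the one measured step, from no change at the digits printed from compound 1 to compound 2 (within the scatter), shows no movement beyond the scatter, so the two measured compounds sit together at the bottom of the scale.

Compound 3, `N#CCN(Cc1ccc(I)cc1)Cc1ccc2ccccc2c1`, has not yet been measured in this assay. It differs from compound 2 in one place: 4-iodophenyl in place of 2-bromophenyl on a saturated chain carbon bound to an amine nitrogen.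

For the measured compounds named here, the step from compound 1 to compound 2 is the only measured change that bears on compound 3, since it also moves a halogen around the same ring on the same saturated chain carbon, and it produced no change. Going by the values given here, with both measured compounds at zero and no step of any size to build on, compound 3 is expected to show a step of a number 3 percentage points higher from compound 2 to compound 3 (within the scatter), that is, nothing beyond the scatter. The estimate for compound 3 in this assay is therefore 3%, expected to fall between -10% and 15%.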

Compound 3, a percentage reported as inhibition, at one concentration (the size of the read-out at that concentration, not a potency): 0%
For compound 3 the middle estimate is 3 percentage points above the measured one, and the stated range covers the measured number.
By their numbers in this assay, from the lowest: compounds 1, 2 and 3 (each within the scatter of the next).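

In this assay the halogen itself is now changed, not only its place on the ring: iodo in place of bromo on an aromatic carbon gives no change at the digits printed from compound 1 to compound 3 (within the scatter) and the move to 4-iodophenyl gives no change at the digits printed from compound 2 to compound 3 (within the scatter) in the series. Neither the heavier halogen nor the earlier shift of bromine lifts the reading, so these three halogenated phenyl groups on the saturated chain carbon cannot be told apart in this read-out. No evidence bears on why this is so.

The three compounds leave open whether a group of another kind on this phenyl ring, such as a carboxylic acid or an amine, would give any inhibition at all. Also open, as far as these compounds go, is whether a reading above zero could be reached with the phenyl ring kept and the nitrile replaced by an amide.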